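The compounds below may be only part of what the source reports. "The series", "measured", "known", "first", "only" and "open" are said of these compounds alone.

Compound 1 `O=C(/C=C/c1cccc(Cl)c1)NNC(=O)c1ccc2c(c1)OCCO2` is one of three close relatives tested in an ADME assay on cells (Macrophage) for cytotoxicity, read by MTT assay, with a stated time of 24 h; on this read-out lower numbers stand for higher toxicity in this test and higher numbers for lower toxicity in this test. Among them compound 1 gives the highest number, 391000 nM. Compound 2 `O=C(/C=C/c1ccccc1)NNC(=O)c1ccc2c(c1)OCCO2` gives 312000 nM, and compound 3 `Cc1cccc(/C=C/C(=O)NNC(=O)c2ccc3c(c2)OCCO3)c1` gives 281000 nM; both differences from compound 1 stay within the ordinary scatter, so no real order among the three can be claimed.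

Compound 4 `Cc1ccccc1/C=C/C(=O)NNC(=O)c1ccc2c(c1)OCCO2` is built from compound 1 by the change (2-methylphenyl in place of 3-chlorophenyl on a double-bonded chain carbon bound to a double-bonded chain carbon). Among the measured compounds shown here, three measured steps bear on this. Removing the chloro gave a 1.3-fold lower number from compound 1 to compound 2 (0.10 log units; within the scatter); swapping chloro for methyl gave a 1.4-fold lower number from compound 1 to compound 3 (0.14 log units; within the scatter); adding a methyl to the bare ring gave a 1.1-fold lower number from compound 2 to compound 3 (0.05 log units; within the scatter). Every one of these is within the scatter, and compound 3 already shows that a methyl on this ring leaves the read-out essentially unchanged. The step to a methyl-bearing ring is therefore expected to be a 1.2-fold lower number from compound 1 to compound 4 (0.09 log units; within the scatter), no change beyond the scatter. Compound 4 is accordingly estimated at 320000 nM in this assay, in a range from 180000 nM to 560000 nM.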

Compound 4, half-maximal cytotoxic concentration: 268000 nM
The estimate for compound 4 lay 1.2-fold (0.08 log units) above the measured number; the range from low to high includes it.
By their numbers in this assay, from the lowest: compounds 4, 3, 2 and 1 (each within the scatter of the next).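

In this assay, the methyl group is tolerated as well in the 2-methylphenyl compound as in the 3-methylphenyl compound, since this shift gives a 1.0-fold lower number from compound 3 to compound 4 (0.02 log units; within the scatter). Adding this methyl to the bare phenyl ring gives a 1.2-fold lower number from compound 2 to compound 4 (0.07 log units; within the scatter), and the full replacement of 3-chlorophenyl by 2-methylphenyl gives a 1.5-fold lower number from compound 1 to compound 4 (0.16 log units; within the scatter), so all four compounds now lie within the scatter of one another. No supporting measurement is at hand to give a cause for this flat read-out.

The compounds shown carry only hydrogen, chloro or methyl on this ring, so it remains open whether an amine or a carboxylic acid there would move the number beyond the scatter. On these data alone, whether a longer chain in place of the methyl would do so is also open.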